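Trimethoxyphenyl pyrazolyl chalcones: a methoxy-to-hydrogen step

The compounds below may be only part of what the source reports. "The series", "measured", "known", "first", "only" and "open" are said of these compounds alone.

Measured so far:
compound 1, `COc1cc(-c2cc(/C=C/C(=O)c3ccc(N)cc3)[nH]n2)cc(OC)c1OC`, 104%
compound 2, `COc1ccc(-c2cc(/C=C/C(=O)c3ccc(N)cc3)[nH]n2)cc1OC`, 102%
compound 3, `COc1cc(C(=O)/C=C/c2cc(-c3cc(OC)c(OC)c(OC)c3)n[nH]2)cc(OC)c1OC`, 97%

In a functional assay on SK-MEL-2 cells (Homo sapiens) for cytotoxicity, read by sulforhodamine B assay, with a stated time of 48 h, tested at 1 uM (on this read-out higher numbers stand for a weaker effect at the one concentration tested and lower numbers for a stronger effect), compound 1 gives 104%. Compound 2 carries hydrogen in place of methoxy on an aromatic carbon and gives 102% in this assay; the step of a number 2 percentage points lower from compound 1 to compound 2 (within the scatter) lies within the scatter. Compound 3 is built differently: the difference between the core of compound 1 and the core of compound 3 is not broken down here. In this assay compound 3 gives 97%, with the values of compound 2 and compound 1 lying within the scatter of it.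

Compound 4, `COc1ccc(-c2cc(/C=C/C(=O)c3cc(OC)c(OC)c(OC)c3)[nH]n2)cc1OC`, is not yet measured. It differs from compound 3 by hydrogen in place of methoxy on an aromatic carbon, the same change that leads from compound 1 to compound 2, on a place described in the same words. Because the step of a number 2 percentage points lower from compound 1 to compound 2 (within the scatter) stayed within the scatter, the step from compound 3 to compound 4 in this assay is expected to be of a similar size, estimated as a number 1 percentage points lower from compound 3 to compound 4 (within the scatter). For compound 4 in this assay the estimate is 96%, expected between 86% and 106%.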

Compound 4, a percentage reported as activity, at one concentration (the size of the read-out at that concentration, not a potency): 97%
Compound 4: middle estimate off by 1 percentage points, on the low side; measured number inside the range.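

In this assay, putting hydrogen in place of methoxy on an aromatic carbon gives no change at the digits printed from compound 3 to compound 4 (within the scatter). Set beside the earlier step, the same change reads alike on the two cores, and no difference between them can be claimed: the same change on two cores in this assay, a number 2 percentage points lower (within the scatter) from compound 1 to compound 2 and no change at the digits printed (within the scatter) from compound 3 to compound 4, 2 percentage points apart, within the scatter of two such steps. This shows that the change stayed within the scatter on both cores at the one concentration tested, but it does not show that the methoxy group is without influence in general, nor that the change would behave the same way at other concentrations, in other cells or on a third core.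

The compounds shown leave open what a different group would do on that aromatic carbon, such as a hydroxyl, a chlorine atom or a carboxylic acid, since methoxy and hydrogen are the only two compared there. They also leave open whether a longer chain in place of the methoxy would give a step beyond the scatter on either core.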